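This account rests on a few compounds, and the source may have more. Where it says the series, first, only, none or still open, it means among the compounds named here.

Working notes on the series. Compound 1 `CCC(=O)N1CCC(NS(=O)(=O)c2ccc(NC(=O)c3ccccc3C)c3ccccc23)CC1` gives 2.5 nM in an assay on L1.2 cells for binding affinity to C-C chemokine receptor type 8 (Homo sapiens); on this read-out higher numbers stand for weaker inhibition and lower numbers for stronger inhibition. Compound 2 `Cc1ccccc1C(=O)Nc1ccc(S(=O)(=O)NC2CCN(C(=O)CCCN)CC2)c2ccccc12` gives 1.6 nM, and compound 3 `Cc1ccccc1C(=O)Nc1ccc(S(=O)(=O)NC2CCN(C(=O)CCCCN)CC2)c2ccccc12` gives 199 nM. Compound 3 thus holds the highest number of the three: the steps of an 80-fold higher number from compound 1 to compound 3 (1.90 log units; beyond the scatter) and a 120-fold higher number from compound 2 to compound 3 (2.09 log units; beyond the scatter) are both large, while a 1.6-fold lower number from compound 1 to compound 2 (0.19 log units; within the scatter) stays within the scatter. Among the measured compounds shown here, the one change that moves the read-out here is lengthening the amine-bearing chain on the acyl group by one carbon, and it does so sharply.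

Compound 4 `Cc1ccccc1C(=O)Nc1ccc(S(=O)(=O)NC2CCN(C(=O)C3CNC3)CC2)c2ccccc12` has not been measured. It differs from compound 3 by azetidin-3-yl in place of 4-aminobutyl on a carbonyl carbon. The amine is kept, but the open chain gives way to a small ring, and the acyl group becomes shorter again. For the measured compounds named here, the steps that bear on this are the two large ones into compound 3, which show that the longer chain carries the penalty, and the flat step from compound 1 to compound 2, which shows that a shorter amine chain costs nothing. Going by the values given here, no measured pair tests a ring at this position, so the direction is taken from chain length only: a return toward the numbers of compound 1 and compound 2 is expected, tempered for the untested ring. For compound 4 the estimate is 8 nM, with a range of 1.5 nM to 60 nM, meaning an expected step of a 25-fold lower number from compound 3 to compound 4 (1.40 log units; beyond the scatter).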

Compound 4, inhibition constant: 1.5 nM
The estimate for compound 4 lay 5.3-fold (0.73 log units) above the measured number; the measured number falls inside the stated range.
By their numbers in this assay, from the lowest: compounds 4, 2 and 1 (each within the scatter of the next); then compound 3.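

Among the compounds shown here, the azetidin-3-yl ring on the carbonyl carbon is the first ring seen at this position, and it is fully tolerated: a 130-fold lower number from compound 3 to compound 4 (2.12 log units; beyond the scatter) clears the whole loss seen with 4-aminobutyl, while a 1.1-fold lower number from compound 2 to compound 4 (0.03 log units; within the scatter) and a 1.7-fold lower number from compound 1 to compound 4 (0.22 log units; within the scatter) both stay within the scatter. The position therefore accepts an ethyl, a 3-aminopropyl and an azetidin-3-yl group without any readable difference, and among the four compounds only the 4-aminobutyl group of compound 3 stands apart. The compounds shown offer no measurement that explains why this one group differs from the other three.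

Going by these compounds, it remains open whether the ring nitrogen contributes at all, which cyclobutyl in place of azetidin-3-yl would address, and whether larger rings such as pyrrolidin-3-yl or piperidin-4-yl, or an N-methyl azetidine, fit as well. The compounds shown do not separate the length of the chain in compound 3 from the terminal amine on that chain. A plain pentyl chain carrying no amine would separate the two.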